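Amide nitrogen variation on the cinnamate ester series

The source may hold more compounds than are shown below. What is called first, only, known or untested is meant among the compounds shown, and "the series" means these compounds.

Compound 1 `COCOc1cc(/C=C/C(=O)OCC(=O)NCc2ccco2)ccc1OCc1ccccc1` bears a (furan-2-yl)methyl group on the amide-type nitrogen. In a functional assay on BEL-7404 cells (Homo sapiens) for cytotoxicity, read by MTT assay, with a stated time of 72 h (a lower number here means a stronger inhibitor, a higher number a weaker inhibitor), compound 1 gives > 200000 nM, a limit of the assay rather than a number. Compound 2 `COCOc1cc(/C=C/C(=O)OCC(=O)NN2CCOCC2)ccc1OCc1ccccc1` bears morpholin-4-yl at that nitrogen. In this assay compound 2 gives > 200000 nM, again only a limit. The step that the two limits leave unreadable from compound 1 to compound 2 is unreadable because of the limit of > 200000 nM in this assay, at which 2 of the 2 values shown sit. For the measured compounds named here, compound 2 therefore stands at the limit, as does the one other value shown. Compound 3 `COCOc1cc(/C=C/C(=O)OCC(=O)Nc2ccc(OC)cc2)ccc1OCc1ccccc1` differs from compound 2 by 4-methoxyphenyl in place of morpholin-4-yl on an amide-type nitrogen. Going by the values given here, no measured step resolves the effect of a change on this nitrogen, since every value sits at the limit. Compound 3 is accordingly expected to stay near the limit, the expected step of a number no higher from compound 2 to compound 3 (the limit leaves the size open) being no larger than the scatter. The estimate for compound 3 in this assay is 200000 nM, with a range from 60000 nM to 600000 nM.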

Compound 3, half-maximal inhibitory concentration: 133000 nM
Compound 3: middle estimate off by 1.5-fold (0.18 log units), on the high side, within the range that was stated.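

In this assay compound 3 gives 133000 nM and is the only compound shown with a number rather than a limit of the assay. On the amide-type nitrogen, 4-methoxyphenyl in place of morpholin-4-yl reads as an at least 1.5-fold lower number from compound 2 to compound 3 (0.17 log units; that floor lies within the scatter) and 4-methoxyphenyl in place of (furan-2-yl)methyl reads as an at least 1.5-fold lower number from compound 1 to compound 3 (0.17 log units; that floor lies within the scatter) with the full size of each step left open. This position can therefore give a readable value with 4-methoxyphenyl, but no gain beyond the scatter is established: the limit of > 200000 nM in this assay, at which 2 of the 3 values shown sit.

Still open, on these data alone, is whether the methoxy group matters, which a plain phenyl or a 4-chlorophenyl on this nitrogen would test. Also open, as far as these compounds go, is how a benzyl group or a longer chain ending in an amine would read at this position.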